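This account rests on a few compounds, and the source may have more. Where it says the series, first, only, none or still open, it means among the compounds named here.

Measured so far in a functional assay on MCF7 cells (Homo sapiens) for inhibition, read by MTT assay, with a stated time of 4 days; a lower number here means a stronger inhibitor, a higher number a weaker inhibitor:

- compound 1 `COc1cc(NC(C)CCCNC(=O)NNC(=O)NCCCCCO)c2ncccc2c1` gives 4000 nM
- compound 2 `COc1cc(NC(C)CCCNC(=O)NNC(=O)NC(CO)(CO)CO)c2ncccc2c1` gives 28000 nM

Compound 2 holds the higher of the two numbers, so it is the weaker inhibitor of this pair. The next compound, compound 3 `COc1cc(NC(C)CCCNC(=O)Nc2ccc(Cl)c(C(F)(F)F)c2)c2ncccc2c1`, puts 4-chloro-3-(trifluoromethyl)phenyl in place of ((2-hydroxy-1,1-bis(hydroxymethyl)ethyl)carbamoyl)amino on an amide-type nitrogen.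

Going by the values given here, only one measured step bears on this change, a 7.0-fold higher number from compound 1 to compound 2 (0.85 log units; beyond the scatter). It swapped just the end group, and that alone moved the number beyond the scatter. Among the compounds with values here, the change to compound 3 is larger, and no measured compound carries this new group, so the forecast is loose. Within the data shown here, since compound 2 sits at the top of the numbers so far, a move to a lower number of similar size seems likely. The expected change is a 9.3-fold lower number from compound 2 to compound 3 (0.97 log units; beyond the scatter). For compound 3 the estimated value is 3000 nM, with an expected range from 700 nM to 13000 nM.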

Compound 3, half-maximal inhibitory concentration: 4000 nM
The estimate for compound 3 lay 1.3-fold (0.12 log units) below the measured number; the range from low to high includes it.
By their numbers in this assay, from the lowest: compounds 1 and 3 (each within the scatter of the next); then compound 2.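

Replacing the ((2-hydroxy-1,1-bis(hydroxymethyl)ethyl)carbamoyl)amino end on this amide-type nitrogen with 4-chloro-3-(trifluoromethyl)phenyl, which has one six-membered aromatic ring and no hydrogen-bond donors, gives a 7.0-fold lower number from compound 2 to compound 3 (0.85 log units; beyond the scatter) in this assay. Replacing the ((5-hydroxypentyl)carbamoyl)amino end with the same aromatic group gives no change at the digits printed from compound 1 to compound 3 (within the scatter), so two very different end groups cannot be told apart at this position, and a ring here is compatible with the lower of the numbers seen so far. No measurement available here accounts for these results.

On these data alone, whether a plain phenyl group, or a chain ending in an amine or a carboxylic acid, would stay level with compound 1 and compound 3 remains open. As far as these compounds go, it is also open how much of the number for compound 3 depends on the chlorine or on the trifluoromethyl group.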